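A few compounds are considered here, and "the series" means these few. Any claim that something is new, unique, unknown or untested is made for them only; others in the source may bear on it.

Measured in an ADME assay on microsomes from liver (Homo sapiens) for metabolic stability, with a stated time of 10 min; on this read-out higher numbers stand for a more stable compound and lower numbers for a less stable compound:
- Compound 1 `COC1(c2nnc3c(Oc4cccc(Cl)c4C)cccn23)CCCCCC1`: < 1%, a limit and not a number
- Compound 2 `Cc1c(Cl)cccc1Oc1cccn2c([C@]34CCC(C[C@H]3O)C4(C)C)nnc12`: 25%
- Compound 3 `Cc1c(Cl)cccc1Oc1cccn2c(C3CCC(C)(O)CC3)nnc12`: 99%

Compound 3 has the highest number, 99%, and the nearest number belongs to compound 2, at 25%. Compound 4 `Cc1c(Cl)cccc1Oc1cccn2c(C3CCCCCC3O)nnc12` has not been measured yet. It carries 2-hydroxycycloheptyl in place of 4-hydroxy-4-methylcyclohexyl on an aromatic carbon.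

Within the data shown here, one measured step bears on this change: a number at least 98 percentage points higher from compound 1 to compound 3 (beyond the scatter), a large one, with 4-hydroxy-4-methylcyclohexyl replacing 1-methoxycycloheptyl. Compound 4 returns to the seven-membered ring of compound 1 but keeps a hydroxy group, which compound 2 also carries at 25%. A fall beyond the scatter is therefore expected, a number 54 percentage points lower from compound 3 to compound 4 (beyond the scatter). For compound 4 the estimated value is 45%, with an expected range of 15% to 80%.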

Compound 4, percent of the compound remaining: 81%
For compound 4 the middle estimate is 36 percentage points below the measured one; the whole stated range lies below it.
By their numbers in this assay, from the lowest: compound 2; then compound 4; then compound 3. At a limit, below all of these: compound 1.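

In this assay, a seven-membered ring at this position is compatible with high stability: 2-hydroxycycloheptyl in place of 1-methoxycycloheptyl gives a number at least 80 percentage points higher from compound 1 to compound 4 (beyond the scatter). The value of compound 1 is a limit and not a number: the limit of < 1% in this assay, at which 1 of the 4 values shown sits.

Changing 4-hydroxy-4-methylcyclohexyl to 2-hydroxycycloheptyl gives only a number 18 percentage points lower from compound 3 to compound 4 (beyond the scatter), although compound 2, which also carries a hydroxy group, gives 25%.

The compounds shown do not separate gaining the hydroxy group from losing the methoxy group. Going by these compounds, how an amine in place of that hydroxy group would behave also stays open.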